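This account rests on a few compounds, and the source may have more. Where it says the series, first, only, none or still open, it means among the compounds named here.

Measured compounds:
compound 1 `CC(C)N(Cc1cccc(OCCCCCC(=O)O)c1)C(=O)c1ccc(-c2cccc(Oc3ccccc3)c2)cc1`
compound 2 `CCOC(=O)CCCCCOc1cccc(CN(C(=O)c2ccc(-c3cccc(OC(C)C)c3)cc2)C(C)C)c1`

Both measured compounds sit at the ceiling of the assay. In an ADME assay on Raji cells (Homo sapiens) for cytotoxicity, read by CellTiter-Glo and resazurin assay, with a stated time of 72 h (a lower number here means that less compound is needed, a higher number that more compound is needed for the effect), compound 1 returns only a limit, > 18700 nM. In this assay compound 2 likewise returns only a limit, > 26000 nM. Within the data shown here, compound 2 therefore stands at a limit rather than at a number, and the one other value shown, that of compound 1, is a limit as well (the limit of > 18700 nM in this assay, at which 1 of the 2 values shown sits; (the limit of > 26000 nM in this assay, at which 1 of the 2 values shown sits)); no measured number separates the two.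

Compound 3 `CCOC(=O)CCCCCOc1cccc(CN(C(=O)c2ccc(-c3cccc(Oc4ccccc4)c3)cc2)C(C)C)c1` differs from compound 2 by phenyl in place of isopropyl on an oxygen on an aromatic ring. Compound 1 already carries the phenoxy group and in this assay gives only a limit. On that basis the step from compound 2 to compound 3 is expected to be none beyond the scatter, with the read-out most likely reported as a limit once more. The expected step that the limit leaves unreadable from compound 2 to compound 3 is accordingly put at no change beyond the scatter. For compound 3 the estimate is 40000 nM, with a range from 15000 nM to 150000 nM.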

Compound 3, half-maximal effective concentration: > 19600 nM
Compound 3: no number, only a limit (the forecaster's own chance of this, stated with the estimate: 85%); the middle value is on the limit's open side.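

Compound 3 also returns only a limit, so no step can be read from compound 2 to compound 3 or from compound 1 to compound 3: the limit of > 19600 nM in this assay, at which 1 of the 3 values shown sits.

The compounds shown leave open what effect, if any, the isopropoxy to phenoxy change or ethyl in place of hydrogen on an oxygen next to a carbonyl group has in this assay.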